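Exchanging the amide substituent on a thiazole-fused core

This account rests on a few compounds, and the source may have more. Where it says the series, first, only, none or still open, it means among the compounds named here.

Measured so far:
- compound 1 `Cc1cccc(C#Cc2nc3c(s2)C(=O)NCC3)c1`: > 10000 nM
- compound 2 `CCCCN1CCc2nc(C#Cc3ccccc3)sc2C1`: 110 nM
- compound 3 `COC1CC(C(=O)N2CCc3nc(C#Cc4ccccc4)sc3C2)C1`: 640 nM

In an assay on HEK293 cells for positive allosteric modulation of metabotropic glutamate receptor 5 (Homo sapiens), read by FLIPR, with a stated time of 1 h (on this read-out higher numbers stand for an effect only at larger amounts of compound and lower numbers for an effect already at smaller amounts), compound 1 gives only a limit, > 10000 nM. Compound 3 holds the highest of the two numbers shown, and the step of a 5.8-fold higher number from compound 2 to compound 3 (0.76 log units; beyond the scatter), a replacement on the ring amine nitrogen, is the only measured change. Compound 4 `O=C(N1CCC(F)CC1)N1CCc2nc(C#Cc3ccccc3)sc2C1` differs from compound 3 at another place: 4-fluoropiperidin-1-yl in place of 3-methoxycyclobutyl on a carbonyl carbon. Among the measured compounds shown here, no measured step touches this carbonyl position, so no size or direction can be taken over, and a change within the scatter is the plain expectation. Compound 4 is therefore estimated at 500 nM, between 150 nM and 1600 nM, a step of a 1.3-fold lower number from compound 3 to compound 4 (0.11 log units; within the scatter).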

Compound 4, half-maximal effective concentration: 74 nM
Beside the measured number, compound 4's estimate is 6.8-fold (0.83 log units) above it; the whole stated range lies above it.
By their numbers in this assay, from the lowest: compounds 4 and 2 (each within the scatter of the next); then compound 3. At a limit, above all of these: compound 1.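

In this assay, the group on the carbonyl carbon clearly matters: an 8.6-fold lower number from compound 3 to compound 4 (0.94 log units; beyond the scatter). The earlier step from butyl to a carbonyl-linked group raised the number, which could have suggested that any carbonyl on the ring nitrogen is a drawback. With 4-fluoropiperidin-1-yl on that carbonyl, however, compound 4 lies within the scatter of compound 2 at 110 nM, so the carbonyl itself need not carry that cost. Nothing shown here explains why this step is so large. From the compounds shown here alone, it remains open whether plain piperidin-1-yl, without the fluorine, or morpholin-4-yl on the same carbonyl would give a similar number.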